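A few compounds are considered here, and "the series" means these few. Any claim that something is new, unique, unknown or untested is made for them only; others in the source may bear on it.

Measured so far in a functional assay on MCF7 cells (Homo sapiens) for antiproliferative activity, with a stated time of 5 days (on this read-out higher numbers stand for weaker inhibition and lower numbers for stronger inhibition), are these values:

- Compound 1 `CCCCc1ccc2[nH]c(-c3ccc(OC)cc3)c(C=O)c2c1` gives 22 nM
- Compound 2 `CCCCc1ccc2[nH]c(-c3ccc(OC)cc3)c(/C=N/NC(=O)c3ccccc3)c2c1` gives 130 nM
- Compound 3 `CCCCc1ccc2[nH]c(-c3ccc(C(F)(F)F)cc3)c(/C=N/NC(=O)c3ccccc3)c2c1` gives 460 nM

Compound 2 stands in the middle of these three numbers, with compound 1 lower and compound 3 higher. Compound 4 `CCCCc1ccc2[nH]c(-c3ccc(OC)cc3)c(/C=N/NC(=O)c3ccccc3OC)c2c1` keeps all of compound 2 except the benzoyl, which becomes (2-methoxyphenyl)carbonyl: methoxy in place of hydrogen on an aromatic carbon ortho to a large group.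

One measured step offers guidance, and only indirectly. a 3.5-fold higher number from compound 2 to compound 3 (0.55 log units; beyond the scatter) is a modest change, and it exchanges trifluoromethyl for methoxy in a different place. Within the data shown here, it shows that one aromatic substituent can move the number in this assay beyond the scatter, but no measured step touches the benzoyl. A step no larger than that one is therefore expected, most likely within the scatter, with a slight lean towards a higher number. The expected step is a 1.4-fold higher number from compound 2 to compound 4 (0.14 log units; within the scatter) as estimated here. For compound 4 the estimate is 180 nM with an expected range from 70 nM to 480 nM in this read-out.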

Compound 4, half-maximal inhibitory concentration: 71 nM
The estimate for compound 4 lay 2.5-fold (0.40 log units) above the measured number; the range from low to high includes it.
By their numbers in this assay, from the lowest: compound 1; then compounds 4 and 2 (each within the scatter of the next); then compound 3.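

In this assay, among these compounds, the change from benzoyl to (2-methoxyphenyl)carbonyl gives a 1.8-fold lower number from compound 2 to compound 4 (0.26 log units; within the scatter), which lies within the scatter and is the first measured step at the benzoyl. It shows that this aromatic carbon, ortho to a large group, carries methoxy in place of hydrogen with no change that can be told from the scatter, whereas the substituent exchange on the other aromatic ring gave a 3.5-fold higher number from compound 2 to compound 3 (0.55 log units; beyond the scatter), which lies beyond it. No measurement is available here that would explain this result.

The compounds shown leave open whether an amine, a carboxylic acid or a longer chain such as butoxy at this same carbon would also stay within the scatter. They also leave open whether methoxy on another carbon of this ring would do the same.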